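This account rests on a few compounds, and the source may have more. Where it says the series, first, only, none or still open, it means among the compounds named here.

Measured so far:
compound 1 `Cc1ccc(-c2nc3ccccc3s2)cc1N`
compound 2 `COc1ccc2nc(-c3ccc(NC(=O)C4CC4)cc3)sc2c1`
compound 3 `CC1(C)O[C@H]2O[C@H]([C@H]3COC(C)(C)O3)[C@H](OCc3ccc(-c4nc5ccc(F)cc5s4)cc3)[C@H]2O1`

In a functional assay on A549 cells (Homo sapiens) for cytotoxicity, read by MTT assay, with a stated time of 2 days (on this read-out lower numbers stand for stronger inhibition and higher numbers for weaker inhibition), compound 1 gives no number, only the limit > 50000 nM. In this assay compound 2 likewise sits at a limit, > 50000 nM. In this assay compound 3 too reaches only a limit, > 50000 nM. So compound 3 stands where every other compound stands: at the edge of what this assay can report, as summed up by the limit of > 50000 nM in this assay, at which 3 of the 3 values shown sit. Among the compounds with values here, no pair of measured compounds differs in one place, so no single step has been measured, and nothing shows whether any change moves the read-out at all.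

Compound 4 `CC1(C)O[C@H]2O[C@H]([C@H](O)CO)[C@H](OCc3ccc(-c4nc5ccc(F)cc5s4)cc3)[C@H]2O1` is yet to be measured. Its difference from compound 3 is 1,2-dihydroxyethyl in place of 2,2-dimethyl-1,3-dioxolan-4-yl on a saturated ring carbon. Within the data shown here, with three compounds all at the same limit and no measured step to lean on, the step expected in this assay is none beyond the scatter, in either direction: the estimate is that the step from compound 3 to compound 4 is a step that the limit leaves unreadable from compound 3 to compound 4. Compound 4 is therefore expected to come out around 80000 nM, within 30000 nM to 300000 nM, most probably again as a limit rather than a number.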

Compound 4, half-maximal inhibitory concentration: 5010 nM
Beside the measured number, compound 4's estimate is 16-fold (1.20 log units) above it; measured number outside the range, below it.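

In this assay, putting 1,2-dihydroxyethyl in place of 2,2-dimethyl-1,3-dioxolan-4-yl on a saturated ring carbon gives an at least 9.9-fold lower number from compound 3 to compound 4 (0.99 log units; beyond the scatter). Within the data shown here, this is the first measured step, and it shows that the read-out responds to a change at this place, on the five-membered non-aromatic ring and next to the ring oxygen, while the rest of compound 3 stays as it is. Compound 4 is also the only compound shown that gives a number rather than a limit: the limit of > 50000 nM in this assay, at which 3 of the 4 values shown sit.

The change removes the five-membered ring and brings in hydrogen-bond donors in one step, so the compounds shown cannot tell which of these two differences goes with the lower number. Also open, from the compounds shown here alone, is whether the read-out would stay low or fall further with other groups on this carbon, such as a single hydroxymethyl, a methoxyethyl chain, an amine or a carboxylic acid, or whether the same change would have any such effect on a different core.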